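Nitro in place of methoxy on the aryl ring

A few compounds are considered here, and "the series" means these few. Any claim that something is new, unique, unknown or untested is made for them only; others in the source may bear on it.

Compound 1 `CC1=C(/C=C/C(=O)/C=C/c2ccc(F)cc2)C(C)(C)CCC1`: 55800 nM
Compound 2 `CC1=C(/C=C/C(=O)/C=C/c2ccc(C#N)cc2)C(C)(C)CCC1`: 45600 nM
Compound 3 `COc1ccc(/C=C/C(=O)/C=C/C2=C(C)CCCC2(C)C)cc1`: > 100000 nM

Three compounds sharing one core were measured in a functional assay on Hep cells (Homo sapiens) for cytotoxicity, read by sulforhodamine B assay, with a stated time of 48 h; on this read-out higher numbers stand for weaker inhibition and lower numbers for stronger inhibition. Compound 1 gives 55800 nM in this assay. Compound 2 gives 45600 nM. For compound 3 only a limit of the assay is known, > 100000 nM, as noted in the limit of > 100000 nM in this assay, at which 1 of the 3 values shown sits.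

Compound 3 therefore stands at the top of the range shown, with no number of its own. The step from compound 1 to compound 2 was a 1.2-fold lower number from compound 1 to compound 2 (0.09 log units; within the scatter). The step from compound 1 to compound 3 was an at least 1.7-fold higher number from compound 1 to compound 3 (0.25 log units; that floor lies within the scatter), and the step from compound 2 to compound 3 was an at least 2.1-fold higher number from compound 2 to compound 3 (0.34 log units; beyond the scatter).

Compound 4 `CC1=C(/C=C/C(=O)/C=C/c2ccc([N+](=O)[O-])cc2)C(C)(C)CCC1` has not yet been measured. It differs from compound 3 by nitro in place of methoxy on an aromatic carbon. For the measured compounds named here, the steps that bear on it are those in which the methoxy group enters, from compound 1 and compound 2 to compound 3, both of which raised the number. Removing the methoxy group again is therefore expected to bring the number back down, a step of about an at least 2.0-fold lower number from compound 3 to compound 4 (0.30 log units; that floor lies within the scatter) in this assay.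

Compound 4 is expected to give about 50000 nM, between 25000 nM and 110000 nM, since compound 2 gave 45600 nM.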

Compound 4, half-maximal inhibitory concentration: 55500 nM
Compound 4: middle estimate off by 1.1-fold (0.05 log units), on the low side, and the stated range covers the measured number.
By their numbers in this assay, from the lowest: compounds 2, 4 and 1 (each within the scatter of the next). At a limit, above all of these: compound 3.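

In this assay, nitro on this aromatic carbon, para to a large group, gives a number that cannot be told apart from those of the cyano and fluoro compounds: the result is a 1.2-fold higher number from compound 2 to compound 4 (0.09 log units; within the scatter), and a 1.0-fold lower number from compound 1 to compound 4 (0.00 log units; within the scatter). Compounds 1, 2 and 4 therefore form a set of three different groups at this place, all within the scatter of one another, so swapping among these three groups does not separably move the read-out. Compound 3 still has only a limit and not a number, so the change from methoxy to nitro, an at least 1.8-fold lower number from compound 3 to compound 4 (0.25 log units; that floor lies within the scatter), is known only as a floor, and that floor does not clear the scatter: the limit of > 100000 nM in this assay, at which 1 of the 4 values shown sits.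

The compounds shown leave open how far the methoxy compound actually lies from the other three, and whether any group at this place can move the number clearly below the level these three share. An amine, a carboxylic acid or a chloro group on the same carbon would test whether that level holds beyond nitro, cyano and fluoro.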